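Working notes: hydroxypyridinyl in place of hydroxyphenyl

This account rests on a few compounds, and the source may have more. Where it says the series, first, only, none or still open, it means among the compounds named here.

Measured so far:
compound 1 `Cc1cccc(NC(=O)CN2CCC(c3ccccc3C#N)CC2)c1` gives 8 nM in a functional assay on HEK293 cells for agonist activity at D(4) dopamine receptor (Homo sapiens), read by FLIPR; on this read-out lower numbers stand for an effect already at smaller amounts and higher numbers for an effect only at larger amounts of compound
compound 2 `Cc1cccc(NC(=O)CN2CCC(c3cccc(O)c3)CC2)c1` gives 8 nM in this assay
compound 3 `O=C(NCN1CCC(c2cccc[n+]2[O-])CC1)c1cc(Cl)cc(Cl)c1` gives 45 nM in this assay

Compound 2 stands level with compound 1 at the digits shown; together they hold the lowest numbers of the three. Compound 3 gives a clearly higher number, and the gap from compound 2 to compound 3 lies beyond the scatter. Compound 4 `Cc1cccc(NC(=O)CN2CCC(c3ccc(O)cn3)CC2)c1` is not yet measured. It differs from compound 2 in one place: 5-hydroxypyridin-2-yl in place of 3-hydroxyphenyl on a saturated ring carbon.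

For the measured compounds named here, only one measured step touches this position, no change at the digits printed from compound 1 to compound 2 (within the scatter), and it shows that an exchange of the aromatic group on this saturated ring carbon left the number unchanged within the scatter. Going by the values given here, no measured pair shows what a ring nitrogen entering the aromatic group does. The step from compound 2 to compound 4 is therefore expected to be small, a 1.9-fold higher number from compound 2 to compound 4 (0.27 log units; within the scatter), leaning if anything to a higher number. For compound 4 the estimated value in this assay is 15 nM, with a range from 5 nM to 50 nM.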

Compound 4, half-maximal effective concentration: 3.8 nM
Compound 4: middle estimate off by 3.9-fold (0.60 log units), on the high side, and the stated range ends above it.
By their numbers in this assay, from the lowest: compound 4; then compounds 1 and 2 (each within the scatter of the next); then compound 3.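

In this assay, for the compounds shown here, a ring nitrogen in the aromatic group is seen for the first time: 5-hydroxypyridin-2-yl in place of 3-hydroxyphenyl gives a 2.1-fold lower number from compound 2 to compound 4 (0.32 log units; beyond the scatter), so this position responds to a change inside the aromatic group, whereas the exchange of 2-cyanophenyl for 3-hydroxyphenyl gave no change at the digits printed from compound 1 to compound 2 (within the scatter). Set against 2-cyanophenyl, the same 5-hydroxypyridin-2-yl gives a 2.1-fold lower number from compound 1 to compound 4 (0.32 log units; beyond the scatter), so both steps to compound 4 lie just beyond the scatter and are modest in size. No measurement at hand gives a reason for this shift.

The compounds shown leave open what the ring nitrogen does without the hydroxyl, as in a plain pyridin-2-yl group, and whether a methoxy group or an amine in place of the hydroxyl keeps the number this low. On these data alone, whether 5-hydroxypyridin-2-yl behaves the same way on the core of compound 3 also remains open.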